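The compounds below may be only part of what the source reports. "The series", "measured", "known", "first", "only" and "open" are said of these compounds alone.

Compound 3 `O=C(CSc1nnc(-c2ccncc2)n1-c1ccccc1)N/N=C/c1ccc([N+](=O)[O-])cc1` carries a 4-nitrophenyl on the carbon with a double bond to nitrogen. In a functional assay on HCT-116 cells (Homo sapiens) for inhibition, read by MTT assay, with a stated time of 48 h (a higher number here means a weaker inhibitor, a lower number a stronger inhibitor), compound 3 gives 10200 nM, the lowest number among the three measured. Compound 2 `O=[N+]([O-])c1cccc(CSc2nnc(-c3ccncc3)n2-c2ccccc2)c1` gives 19800 nM in this assay, a gap that lies within the scatter, and compound 1 `Fc1cccc(F)c1CSc1nnc(-c2ccncc2)n1-c1ccccc1` gives 22100 nM, a gap beyond it. Compound 4 `O=C(CSc1nnc(-c2ccncc2)n1-c1ccccc1)N/N=C/c1cc(Br)ccc1O` is not yet measured; it differs from compound 3 in one place: 5-bromo-2-hydroxyphenyl in place of 4-nitrophenyl on a carbon with a double bond to nitrogen. Among the compounds with values here, the only measured step that exchanges a single aryl group is a 1.1-fold lower number from compound 1 to compound 2 (0.05 log units; within the scatter); there the exchanged group sits on a saturated chain carbon bound to a sulfur rather than on the carbon with a double bond to nitrogen, and the step stayed within the scatter. Within the data shown here, no measured step exchanges the group on the carbon with a double bond to nitrogen, and no measured compound carries a 5-bromo-2-hydroxyphenyl, so the evidence bearing on the present change is indirect. On that evidence the expected step in this assay for compound 4 is a 1.0-fold lower number from compound 3 to compound 4 (0.01 log units; within the scatter), nothing beyond the scatter in either direction. Compound 4 is therefore estimated at 10000 nM in this assay, with a range from 4000 nM to 25000 nM.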

Compound 4, half-maximal inhibitory concentration: 1990 nM
Estimate against measurement, compound 4: 5.0-fold (0.70 log units) above; measured number below the stated range.
By their numbers in this assay, from the lowest: compound 4; then compounds 3, 2 and 1 (each within the scatter of the next, the first and the last beyond it).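

In this assay, within the data shown here, the aryl group on the carbon with a double bond to nitrogen is the first place where a single exchange moves the number beyond the scatter: a 5.1-fold lower number from compound 3 to compound 4 (0.71 log units; beyond the scatter). The earlier exchange on a saturated chain carbon bound to a sulfur, a 1.1-fold lower number from compound 1 to compound 2 (0.05 log units; within the scatter), stayed within the scatter, so of the two places examined, only this one has shown a step of that size, a reading that rests on one pair at each place. The exchange also alters several things at once, with 4-nitrophenyl leaving and a ring bearing both bromine and a hydroxyl entering, and nothing measured here explains the gain or assigns it to either substituent.

The compounds shown leave open whether the hydroxyl, the bromine or the two together carry the step, a question that a phenyl bearing only one of them, or a methoxy in place of the hydroxyl, would address. Also open, from the compounds shown here alone, is how an unsubstituted phenyl or a chlorine in place of the bromine would read at this place.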